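Swapping the ring on the carbonyl carbon of compound 2

A few compounds are considered here, and "the series" means these few. Any claim that something is new, unique, unknown or untested is made for them only; others in the source may bear on it.

In an in vitro ADME assay on microsomes from liver (Rattus norvegicus) for metabolic stability (a higher number here means that the compound lasts longer, a lower number that the compound disappears faster), compound 1 `CC(=O)c1cc(C(=O)NOCCCO)c(Nc2ccc(I)cc2F)n1C` gives a half-life of 0.217 h, and compound 2 `CC(=O)c1cc(C(=O)N2CC(N)C2)c(Nc2ccc(I)cc2F)n1C` gives 1.07 h, the higher of the two numbers. Compound 3 `CC(=O)c1cc(C(=O)N2CC[C@@H](O)C2)c(Nc2ccc(I)cc2F)n1C` has not yet been measured. It carries 3-hydroxypyrrolidin-1-yl in place of 3-aminoazetidin-1-yl on a carbonyl carbon, and the change counts as 3-hydroxypyrrolidin-1-yl in place of 3-aminoazetidin-1-yl on a carbonyl carbon. Within the data shown here, only one measured step bears on this place: a 4.9-fold higher number from compound 1 to compound 2 (0.69 log units; beyond the scatter), with 3-aminoazetidin-1-yl replacing (3-hydroxypropoxy)amino on the same carbonyl carbon. That step lies beyond the scatter, but it does not exchange one ring for another, so it offers only a loose guide. In this assay, a slight fall that stays within the scatter is expected, with an estimated step of a 1.3-fold lower number from compound 2 to compound 3 (0.13 log units; within the scatter). For compound 3 the expected half-life is 0.8 h, with an estimated range of 0.3 h to 2.1 h.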

Compound 3, half-life: 0.15 h
Estimate against measurement, compound 3: 5.3-fold (0.73 log units) above; measured number outside the range, below it.
By their numbers in this assay, from the lowest: compounds 3 and 1 (each within the scatter of the next); then compound 2.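

In this assay, the group on this carbonyl carbon proves sensitive to an exchange of one ring for another: 3-hydroxypyrrolidin-1-yl in place of 3-aminoazetidin-1-yl gives a 7.1-fold lower number from compound 2 to compound 3 (0.85 log units; beyond the scatter), a step beyond the scatter. A ring at this place is therefore not enough on its own to hold the longer half-life of compound 2, and a 1.4-fold lower number from compound 1 to compound 3 (0.16 log units; within the scatter) leaves compound 3 indistinguishable from compound 1, which carries (3-hydroxypropoxy)amino there. Nothing given here explains the difference between the two rings.

Compound 2 and compound 3 differ at once in ring size and in the amine or hydroxyl group on the ring, so the two changes cannot be separated. A 3-aminopyrrolidin-1-yl or 3-hydroxyazetidin-1-yl group on the same carbonyl carbon would pull them apart, and the opposite stereocentre of 3-hydroxypyrrolidin-1-yl remains an open question.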